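Chloro for methyl on the aniline analogue of compound 2

The source may hold more compounds than are shown below. What is called first, only, known or untested is meant among the compounds shown, and "the series" means these compounds.

Compound 2 `Cc1ccc(CN2C(=O)S/C(=C\c3cccc(N)c3)C2=O)cc1`, the analogue without the (1-bromoethenyl)carbonyl group, sits at the upper limit of a functional assay on CCRF-CEM cells (Homo sapiens) for cytotoxicity, read by cell counting, with a stated time of 3 days (on this read-out lower numbers stand for stronger inhibition and higher numbers for weaker inhibition), and compound 2 gives > 250000 nM, a limit of the assay rather than a number. Compound 1 `C=C(Br)C(=O)Nc1cccc(/C=C2\SC(=O)N(Cc3ccc(C)cc3)C2=O)c1` gives 1200 nM in this assay, so an at least 200-fold higher number from compound 1 to compound 2 (2.31 log units; beyond the scatter) marks the loss of that group. Compound 3 `Cc1ccc(CN2C(=O)S/C(=C\c3ccc(N)cc3)C2=O)cc1` also reaches only a limit, giving > 250000 nM, and a step that the two limits leave unreadable from compound 2 to compound 3 cannot be read because of the limit of > 250000 nM in this assay, at which 2 of the 3 values shown sit. Compound 4 `Nc1cccc(/C=C2\SC(=O)N(Cc3ccc(Cl)cc3)C2=O)c1` differs from compound 2 by chloro in place of methyl on an aromatic carbon, on an aromatic carbon of a six-membered aromatic ring of carbon only. Going by the values given here, no measured step touches this position, and compound 4 also lacks the group whose loss gave the one large step. Compound 4 is therefore expected to stay at the limit, with a number no higher from compound 2 to compound 4 (the limit leaves the size open) within scatter. The estimate for compound 4 is 250000 nM, range 100000 nM to 600000 nM.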

Compound 4, half-maximal inhibitory concentration: > 250000 nM
Compound 4: only a limit was reported; the forecaster's own chance of this, stated with the estimate: 85%; the middle value sits exactly at the limit.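

No step between compound 2 and compound 4 can be read, because both sit at a limit: the limit of > 250000 nM in this assay, at which 3 of the 4 values shown sit.

Still open, on these data alone, is whether chloro in place of methyl changes the number when the (1-bromoethenyl)carbonyl group is present, as in compound 1.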